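A few compounds are considered here, and "the series" means these few. Any claim that something is new, unique, unknown or untested is made for them only; others in the source may bear on it.

In a functional assay on U-251 cells (Homo sapiens) (a lower number here means a stronger inhibitor of growth, a higher number a weaker inhibitor of growth), compound 1 (`O=S(=O)(/C=C/c1ccc(C(F)(F)F)cc1F)Cc1ccc(Nc2ncnc3ccccc23)cc1`) gives 100000 nM and compound 2 (`O=S(=O)(/C=C/c1ccc(F)cc1F)Cc1ccc(Nc2ncnc3ccc(Br)cc23)cc1`) gives 32000 nM while compound 3 (`COc1cc2ncnc(Nc3ccc(CS(=O)(=O)/C=C/c4ccc(Cl)cc4Cl)cc3)c2cc1OC`) gives 13000 nM as the lowest of the three numbers, clear of both others beyond the scatter. Growth inhibition in this set is weak throughout, and all three numbers sit high on the scale.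

The step to compound 4 (`COc1cc2ncnc(Nc3ccc(CS(=O)(=O)/C=C/c4ccc(Br)cc4)cc3)c2cc1OC`) is 4-bromophenyl in place of 2,4-dichlorophenyl on a double-bonded chain carbon bound to a double-bonded chain carbon and puts 4-bromophenyl in place of 2,4-dichlorophenyl on a double-bonded chain carbon bound to a double-bonded chain carbon. The core stays that of compound 3.

For the measured compounds named here, no pair of measured compounds differs in one place only, so the series gives no direct measure of this change. Compounds 1 and 2 differ from compound 3 in more than one place. Compound 3 at 13000 nM is therefore the anchor for the expectation. The expected step of a 1.2-fold higher number from compound 3 to compound 4 (0.06 log units; within the scatter) stays within the scatter in size, with no direction favoured. The estimate for compound 4 is 15000 nM with an expected range from 5000 nM to 45000 nM for the measurement.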

Compound 4, concentration for 50% growth inhibition: 11000 nM
Compound 4: middle estimate off by 1.4-fold (0.13 log units), on the high side, within the range that was stated.
By their numbers in this assay, from the lowest: compounds 4 and 3 (each within the scatter of the next); then compound 2; then compound 1.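

For the compounds shown here, the first pair that differs in one place gives a 1.2-fold lower number from compound 3 to compound 4 (0.07 log units; within the scatter) in this assay. At a double-bonded chain carbon bound to a double-bonded chain carbon, 2,4-dichlorophenyl and 4-bromophenyl therefore cannot be told apart in this read-out, although they differ in halogen and in number of halogens, and the pair stays high on the scale. No measurement shown accounts for this.

Still open, going by these compounds, is whether a group without halogen in place of 4-bromophenyl, such as a pyridine ring or a phenyl carrying a carboxylic acid or an amine, would move the number beyond the scatter. Going by these compounds alone, also open is how the differences in the core among compounds 1, 2 and 3 bear on growth inhibition, since no one-place pair covers them.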